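Cytotoxicity notes: a hexylsulfanyl analogue of compound 3

The source may hold more compounds than are shown below. What is called first, only, known or untested is meant among the compounds shown, and "the series" means these compounds.

Compound 3 `CC(C)CNc1nc(N)nc2c1ncn2/C=C1/CC1(CO)CO` stands at the limit of an ADME assay on CCRF-HSB-2 cells (Homo sapiens) for cytotoxicity, with a stated time of 7 days (on this read-out lower numbers stand for higher toxicity in this test and higher numbers for lower toxicity in this test), where it gives > 20000 nM, a limit of the assay and not a number. Compound 1 `CCCCCCCCOc1nc(N)nc2c1ncn2/C=C1/CC1(CO)CO` reaches the same kind of limit, > 20000 nM. Compound 2 `CCCNc1nc(N)nc2c1ncn2/C=C1/CC1(CO)CO` likewise stops at the limit > 20000 nM. The steps leading to compound 3, a step that the two limits leave unreadable from compound 1 to compound 3 and a step that the two limits leave unreadable from compound 2 to compound 3, therefore stay unreadable, as does a step that the two limits leave unreadable from compound 1 to compound 2. All three values sit at the limit of > 20000 nM in this assay, at which 3 of the 3 values shown sit. Compound 4 `CCCCCCSc1nc(N)nc2c1ncn2/C=C1/CC1(CO)CO` carries hexylsulfanyl in place of isobutylamino on an aromatic carbon. Going by the values given here, no measured step yields a size or direction, so no shift beyond the scatter is expected in this assay; compound 4 is expected to show a step that the limit leaves unreadable from compound 3 to compound 4. Compound 4 is estimated at 30000 nM, from 15000 nM to 80000 nM, most probably reported again as a limit.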

Compound 4, half-maximal cytotoxic concentration: 60000 nM
Beside the measured number, compound 4's estimate is 2.0-fold (0.30 log units) below it, and the stated range covers the measured number.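

Compound 1, compound 2 and compound 3 each stand at a limit, so no step to compound 4 can be read in this assay: the limit of > 20000 nM in this assay, at which 3 of the 4 values shown sit.

The compounds shown leave open how the groups on this aromatic carbon rank against one another, with only compound 4 giving a number.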